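The source may hold more compounds than are shown below. What is called first, only, known or untested is meant among the compounds shown, and "the series" means these compounds.

In a functional assay on HT-29 cells (Homo sapiens) for antiproliferative activity, with a stated time of 48 h (on this read-out higher numbers stand for weaker inhibition and lower numbers for stronger inhibition), three related compounds have been measured. Compound 1 `CCCCC(O)c1cccc(NC(=O)CCCl)c1` gives only a limit of the assay, > 100000 nM, rather than a number. Compound 2 `CCCCC(OC)c1cccc(NC(=O)CCCl)c1` differs from compound 1 by a single change, (methyl in place of hydrogen on an oxygen on a saturated carbon). Compound 2 likewise gives only a limit, > 100000 nM. The step between them therefore reads as a step that the two limits leave unreadable from compound 1 to compound 2. Compound 3 `CCCCC(O)c1cccc(NC(=O)CCCCl)c1` has a different core from compound 1; the difference is chloromethyl in place of chloro on a saturated chain carbon, two bonds along the chain from a carbonyl carbon. Compound 3 also gives only a limit, > 100000 nM. This step too reads as a step that the two limits leave unreadable from compound 1 to compound 3. Going by the values given here, every measured value so far sits at the limit of > 100000 nM in this assay, at which 3 of the 3 values shown sit, so neither change can be given a size.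

Compound 4 `CCCCC(OC)c1cccc(NC(=O)CCCCl)c1` has not yet been measured. It differs from compound 3 by methyl in place of hydrogen on an oxygen on a saturated carbon, the same change as from compound 1 to compound 2, at the same place. Because all three measured values sit at the limit of > 100000 nM in this assay, at which 3 of the 3 values shown sit, compound 4 is expected to stay at or beyond that limit as well, an expected step that the limit leaves unreadable from compound 3 to compound 4. The estimate for compound 4 is 150000 nM, within a range from 50000 nM to 500000 nM.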

Compound 4, half-maximal inhibitory concentration: > 100000 nM
Compound 4: a limit, no number; the forecaster's own chance of this, stated with the estimate: 85%; the middle value does not contradict the limit.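

In this assay compound 4 gives only a limit, > 100000 nM, so the steps to it from compound 3 and from compound 2 cannot be read: the limit of > 100000 nM in this assay, at which 4 of the 4 values shown sit.

The compounds shown leave open whether hydroxy to methoxy, or chloromethyl in place of chloro, changes antiproliferative activity at all, as none of them gives a number.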